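Swapping a Cyanobenzyl Arm for Butyl on the Core

A few compounds are considered here, and "the series" means these few. Any claim that something is new, unique, unknown or untested is made for them only; others in the source may bear on it.

compound 1 `CCCCc1cnc(C(C)Cc2ccc(-c3ccccc3C(=O)O)cc2)[nH]1` — 184 nM
compound 2 `Cc1ccccc1Cc1cnc(CCc2ccc(-c3ccccc3C(=O)O)cc2)[nH]1` — 9.3 nM
compound 3 `N#Cc1ccc(Cc2cnc(CCc3ccc(-c4ccccc4C(=O)O)cc3)[nH]2)cc1` — 723 nM

In an in vitro functional assay on cells for agonist activity at Bombesin receptor subtype-3 (Mus musculus), read by luminescence and calcium flux (on this read-out higher numbers stand for an effect only at larger amounts of compound and lower numbers for an effect already at smaller amounts), compound 3 gives 723 nM, the highest of the three numbers; nearest to it is compound 1 with 184 nM, and furthest away is compound 2 with 9.3 nM. Compound 4 `CCCCc1cnc(CCc2ccc(-c3ccccc3C(=O)O)cc2)[nH]1` differs from compound 3 by a single change: propyl in place of 4-cyanophenyl on a saturated chain carbon bound to an aromatic carbon. Within the data shown here, one measured step touches the same place, a 78-fold higher number from compound 2 to compound 3 (1.89 log units; beyond the scatter), showing that what sits there can move the number a great deal. Among the measured compounds shown here, no measured pair shows this exact exchange, but compound 1 also carries a butyl group there and gives 184 nM, differing from compound 4 only slightly elsewhere. Compound 4 is therefore expected to land well below compound 3, a step of a 4.8-fold lower number from compound 3 to compound 4 (0.68 log units; beyond the scatter). The estimate for compound 4 is 150 nM, between 40 nM and 500 nM.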

Compound 4, half-maximal effective concentration: 93 nM
Beside the measured number, compound 4's estimate is 1.6-fold (0.21 log units) above it; low and high end bracket the measured number.
By their numbers in this assay, from the lowest: compound 2; then compounds 4 and 1 (each within the scatter of the next); then compound 3.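

A plain butyl chain with no ring gives a lower number than the 4-cyanobenzyl arm (a 7.8-fold lower number from compound 3 to compound 4 (0.89 log units; beyond the scatter)) but a higher number than the arm carrying 2-methylphenyl (a 10-fold higher number from compound 2 to compound 4 (1.00 log units; beyond the scatter)), so among these compounds, a ring at this place can either help or hurt. The methyl that separates compound 1 from compound 4 makes no readable difference (a 2.0-fold lower number from compound 1 to compound 4 (0.30 log units; within the scatter)), so the butyl result holds with or without it. Nothing available explains these differences. Still open, as far as these compounds go, is how a longer chain, or an amine at the end of the butyl chain, would compare.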